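The source may hold more compounds than are shown below. What is called first, only, known or untested is meant among the compounds shown, and "the series" means these compounds.

Three compounds share one core and differ only in a single group on an aromatic carbon. In an in vitro assay on HEK-tsA201 cells for antagonist activity at Neuronal acetylcholine receptor; alpha4/beta2 (Homo sapiens), read by fluorescence and calcium flux (on this read-out lower numbers stand for stronger inhibition and higher numbers for weaker inhibition), compound 1 `C=CCOc1ccc(C(=O)Nc2cccc(Br)n2)cc1` gives 70100 nM. Compound 2 `C=CCOc1ccc(C(=O)Nc2cccc(CC)n2)cc1` gives 20500 nM in this assay, a change of a 3.4-fold lower number from compound 1 to compound 2 (0.53 log units; beyond the scatter). Compound 3 `C=CCOc1ccc(C(=O)Nc2cccc(NCCC)n2)cc1` gives 14800 nM in this assay; the step of a 4.7-fold lower number from compound 1 to compound 3 (0.68 log units; beyond the scatter) lies beyond the scatter, whereas a 1.4-fold lower number from compound 2 to compound 3 (0.14 log units; within the scatter) stays within it. On the numbers shown, compound 3 has the lowest value, but its gap to compound 2 cannot be separated from repeat-measurement noise, and only compound 1 stands clearly apart.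

Compound 4 `C=CCOc1ccc(C(=O)Nc2cccc(NCCCC)n2)cc1` extends the chain of compound 3: methyl in place of hydrogen on a saturated chain carbon, three bonds along the chain from a nitrogen on an aromatic ring. Among the compounds with values here, none of the measured steps lengthens a chain in this way. The closest comparison is a 1.4-fold lower number from compound 2 to compound 3 (0.14 log units; within the scatter), which exchanges one small group for another and lands within the scatter. On that basis no step beyond the scatter is expected from compound 3 to compound 4 in this assay, in either direction. The expected step is a 1.2-fold lower number from compound 3 to compound 4 (0.09 log units; within the scatter). Compound 4 is estimated to give 12000 nM in this assay, with a likely range from 5000 nM to 30000 nM.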

Compound 4, half-maximal inhibitory concentration: 22400 nM
For compound 4 the middle estimate is 1.9-fold (0.27 log units) below the measured one; the measured number falls inside the stated range.
By their numbers in this assay, from the lowest: compounds 3, 2 and 4 (each within the scatter of the next); then compound 1.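

In this assay, going from propyl to butyl on the amino group gives (a 1.5-fold higher number from compound 3 to compound 4 (0.18 log units; within the scatter)), so this first test of chain length at this position shows no change that can be told from repeat-measurement noise. Butylamino in place of ethyl gives (a 1.1-fold higher number from compound 2 to compound 4 (0.04 log units; within the scatter)), which is also within the scatter, so compound 2, compound 3 and compound 4 cannot be ranked against one another on these numbers. Butylamino in place of bromo gives (a 3.1-fold lower number from compound 1 to compound 4 (0.50 log units; beyond the scatter)), which is beyond the scatter, so compound 4 joins ethyl-bearing compound 2 and propylamino-bearing compound 3 in standing clearly apart from compound 1, though only modestly.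

The compounds shown leave open whether a longer chain such as hexylamino, a branched one such as isopropylamino or a plain amino group at this position would stay level with these three or move clearly away from them. Nothing available here accounts for the gap to the bromo compound or for the flat result across the two amino chains.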